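The compounds below may be only part of what the source reports. "The series", "measured", "known", "first", "only" and "open" are said of these compounds alone.

Measured compounds:
- compound 1 `COc1ccc(C#Cc2cc(OC)c(OC)c(OC)c2)cc1N`; this value is a limit of the assay: > 30000 nM
- compound 2 `COc1ccc(C#Cc2cc(OC)c(OC)c(OC)c2)cc1NC(=O)OC(C)(C)C`; this value is a limit of the assay: > 30000 nM
- compound 3 `COc1ccc(C2CC2c2cc(OC)c(OC)c(OC)c2)cc1NC(=O)OC(C)(C)C`; 11800 nM

In a functional assay on MCF7 cells (Homo sapiens) for cytotoxicity, read by MTT assay (a higher number here means a weaker inhibitor, a lower number a stronger inhibitor), compound 1 gives > 30000 nM, which is a limit and not a number. In this assay compound 2 likewise gives > 30000 nM, again a limit. Both values sit at the limit of > 30000 nM in this assay, at which 2 of the 3 values shown sit. Compound 3 is the only one of the three with a number: in this assay compound 3 gives 11800 nM.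

Within the data shown here, the one change made between measured compounds is hydrogen in place of tert-butoxycarbonyl on a nitrogen on an aromatic ring; its size is a step that the two limits leave unreadable from compound 2 to compound 1. Compound 3 and compound 2 differ in their cores, and that difference is not broken down here.

Compound 4 `COc1ccc(C2CC2c2cc(OC)c(OC)c(OC)c2)cc1N` is not yet measured. It stands to compound 3 as compound 1 stands to compound 2: hydrogen in place of tert-butoxycarbonyl on a nitrogen on an aromatic ring. The place of the change reads the same word for word in both pairs, so this is the same change, made a second time on the core of compound 3.

The earlier step gives no readable size, so the expectation for compound 4 rests only on compound 3 and its value 11800 nM. The step from compound 3 to compound 4 is estimated at a 1.3-fold higher number from compound 3 to compound 4 (0.10 log units; within the scatter), close to no change. Compound 4 is therefore expected to give about 15000 nM in this assay, with an estimated range from 4000 nM to 30000 nM, and a real chance that only a limit is reported.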

Compound 4, half-maximal inhibitory concentration: 212 nM
Compound 4: middle estimate off by 71-fold (1.85 log units), on the high side; the whole stated range lies above it.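

In this assay, hydrogen in place of tert-butoxycarbonyl on a nitrogen on an aromatic ring gives a 56-fold lower number from compound 3 to compound 4 (1.75 log units; beyond the scatter), so on the core of compound 3 the change has a large effect and the compound with the free amino group is the stronger of the pair. On the core of compound 1 the same change cannot be read, because compound 2 and compound 1 each stop at a limit and not at a number: the limit of > 30000 nM in this assay, at which 2 of the 4 values shown sit. The series therefore holds only one readable size for this change, which shows what it does on one core but neither confirms nor rules out that it carries to the other, and the size seen on the core of compound 3 should not be assumed elsewhere.

On these data alone, it remains open whether the effect depends on a free amino group or only on the absence of tert-butoxycarbonyl, a question that acetyl or methyl on that nitrogen of the core of compound 3 would address. A hydroxyl group in place of the amino group on that core would likewise test how far the result depends on the nitrogen.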